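This account rests on a few compounds, and the source may have more. Where it says the series, first, only, none or still open, it means among the compounds named here.

Compound 1 `C#CCSc1nc(Nc2ccc([N+](=O)[O-])cc2)c2ccncc2n1` in a functional assay on PC-3 cells (Homo sapiens) for inhibition, read by MTT assay, with a stated time of 72 h (a lower number here means a stronger inhibitor, a higher number a weaker inhibitor), gives > 80000 nM, a limit of the assay.
Compound 2 `C#CCSc1nc(N2CCN(C)CC2)c2ccncc2n1` in this assay gives > 80000 nM, also a limit.
Compound 3 `C#CCSc1nc(N2CCN(CC)CC2)c2ccncc2n1` in this assay gives > 80000 nM, again a limit.

Compound 3 thus stands only at a limit, as do the other two; all three values sit at the limit of > 80000 nM in this assay, at which 3 of the 3 values shown sit, and no order among them can be read. Among the compounds with values here, the single measured step on the ring nitrogen, a step that the two limits leave unreadable from compound 2 to compound 3, lies between two limits and is unreadable. Compound 4 `C#CCSc1nc(N2CCN(C(=O)OC(C)(C)C)CC2)c2ccncc2n1` differs from compound 3 by tert-butoxycarbonyl in place of ethyl on an amine nitrogen in a ring. No readable step bears on this change, and nothing in the data points to a gain; the expected step that the limit leaves unreadable from compound 3 to compound 4 is therefore no readable change. Compound 4 is estimated at 100000 nM, range 40000 nM to 300000 nM, most likely reported again only as a limit.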

Compound 4, half-maximal inhibitory concentration: 47500 nM
Estimate against measurement, compound 4: 2.1-fold (0.32 log units) above, within the range that was stated.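

Within the data shown here, on the amine nitrogen in the ring, tert-butoxycarbonyl gives the only value in this assay so far that is a number and not a limit: compound 4 gives 47500 nM. With tert-butoxycarbonyl in place of ethyl the step is an at least 1.6-fold lower number from compound 3 to compound 4 (0.22 log units; that floor lies within the scatter), and in place of methyl it is an at least 1.6-fold lower number from compound 2 to compound 4 (0.22 log units; that floor lies within the scatter). Both are floors, so a real step at this position is possible but not shown beyond the scatter.

Going by these compounds, whether the step belongs to the carbonyl or to the tert-butyl part remains open. So does what an acetyl or benzyl group would give on this nitrogen.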